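The compounds below may be only part of what the source reports. "The series", "measured", "known", "first", "only" and "open" are said of these compounds alone.

Measured so far in an ADME assay on the whole organism for pharmacokinetics, with Rattus norvegicus as the target, at a dose of 5 mg/kg by the oral route (on this read-out lower numbers stand for lower exposure and higher numbers for higher exposure at the dose given), are these compounds:
compound 1 `Cc1nc(-c2nc[nH]n2)ccc1-c1cnc2c(n1)N(CC1CCOCC1)C(=O)CN2` gives 230 nM
compound 2 `Cc1nc(-c2nc[nH]n2)ccc1-c1cnc2c(n1)N(C(C)C)C(=O)CN2` gives 2080 nM
compound 3 `O=C1CN(CCC2CCOCC2)c2nc(-c3ccc(-c4nc[nH]n4)nc3)cnc2N1` gives 20 nM

Compound 2 stands highest of the three, with compound 1 nearest and compound 3 furthest. Among the compounds with values here, compound 3 differs from compound 2 in more than one place, so it offers no single-change step.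

Compound 4 `COCCN1C(=O)CNc2ncc(-c3ccc(-c4nc[nH]n4)nc3C)nc21` is still unmeasured. It carries 2-methoxyethyl in place of isopropyl on an amide-type nitrogen in a ring, counted as 2-methoxyethyl in place of isopropyl on an amide-type nitrogen in a ring here. Within the data shown here, the only measured step at this nitrogen is a 9.0-fold higher number from compound 1 to compound 2 (0.96 log units; beyond the scatter) with isopropyl in place of (oxan-4-yl)methyl. Read backwards, that pair links leaving isopropyl for an oxygen-bearing chain to a lower number, with compound 1 at 230 nM as the guide. A single pair is thin support, so a drop of lesser size is expected in this assay and it may stay within the scatter. The expected change is a 3.0-fold lower number from compound 2 to compound 4 (0.47 log units; beyond the scatter) on this estimate. Compound 4 is estimated at 700 nM, with an expected range of 200 nM to 2000 nM.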

Compound 4, maximal plasma concentration: 1960 nM
Compound 4: middle estimate off by 2.8-fold (0.45 log units), on the low side; measured number inside the range.
By their numbers in this assay, from the lowest: compound 3; then compound 1; then compounds 4 and 2 (each within the scatter of the next).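

In this assay the move from isopropyl to 2-methoxyethyl on the amide-type nitrogen in a ring gives a 1.1-fold lower number from compound 2 to compound 4 (0.03 log units; within the scatter) and so leaves the read-out unchanged within the scatter, showing that this position accepts a chain carrying an oxygen without loss of exposure. The other new step, methoxymethyl in place of oxan-4-yl on a saturated chain carbon bound to that nitrogen, gives an 8.5-fold higher number from compound 1 to compound 4 (0.93 log units; beyond the scatter) and ties the low number of compound 1 to the oxan-4-yl group rather than to the presence of oxygen alone. No measurement bears on the reason for either step.

As far as these compounds go, a longer chain ending in methoxy remains open at this nitrogen. So does a chain ending in an amine or a carboxylic acid, and whether exposure would hold with either.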